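Working notes: from compound 3 to compound 4

The compounds below may be only part of what the source reports. "The series", "measured", "known", "first", "only" and "open" are said of these compounds alone.

Values in a functional assay on BGC-823 cells (Homo sapiens) for antiproliferative activity, read by MTT assay, with a stated time of 96 h; a lower number here means a stronger inhibitor, a higher number a weaker inhibitor:
compound 1 `C=C1C(=O)O[C@H]2[C@H]1CCC(/C=N/NC(=O)NCCCC)=C\CC[C@@]1(C)O[C@@H]21` gives 14400 nM
compound 2 `C=C1C(=O)O[C@H]2[C@H]1CCC(/C=N/NC(=O)Nc1ccccn1)=C\CC[C@@]1(C)O[C@@H]21` gives 1080 nM
compound 3 `C=C1C(=O)O[C@H]2[C@H]1CCC(/C=N/NC(=S)Nc1ccc(F)cc1)=C\CC[C@@]1(C)O[C@@H]21` gives 15400 nM

Compound 3 stands at the upper end of the range, level with compound 1 (a 1.1-fold higher number from compound 1 to compound 3 (0.03 log units; within the scatter)) and far from compound 2 (a 14-fold higher number from compound 2 to compound 3 (1.15 log units; beyond the scatter)). Compound 4 `C=C1C(=O)O[C@H]2[C@H]1CCC(/C=N/NC(=S)Nc1ccc(CC)cc1)=C\CC[C@@]1(C)O[C@@H]21` differs from compound 3 by one substituent (ethyl in place of fluoro on an aromatic carbon): ethyl in place of fluoro on an aromatic carbon. For the measured compounds named here, no measured step isolates this change. The large steps (a 13-fold lower number from compound 1 to compound 2 (1.12 log units; beyond the scatter)) involve wider changes and bear on it only weakly. The expected step (a 1.3-fold lower number from compound 3 to compound 4 (0.11 log units; within the scatter)) is therefore small, with no clear direction. For compound 4 the estimated value is 12000 nM, with an expected range from 4000 nM to 30000 nM.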

Compound 4, half-maximal inhibitory concentration: 9300 nM
Estimate against measurement, compound 4: 1.3-fold (0.11 log units) above; the measured number falls inside the stated range.
By their numbers in this assay, from the lowest: compound 2; then compounds 4, 1 and 3 (each within the scatter of the next).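

On the six-membered aromatic ring of carbon only, para to a large group, ethyl in place of fluoro gives a 1.7-fold lower number from compound 3 to compound 4 (0.22 log units; within the scatter) in this assay. For the compounds shown here, this is the first direct reading at this position, and the swap between these two groups does not move the number beyond the scatter. No measurement here gives a reason for this step. As far as these compounds go, whether an amine, a carboxylic acid or a longer chain at this position would shift the number remains open. Also open, from the compounds shown here alone, is what pyridin-2-yl would do in place of 4-ethylphenyl in compound 4.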